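Halogen size and paw edema: chloro to fluoro

A few compounds are considered here, and "the series" means these few. Any claim that something is new, unique, unknown or untested is made for them only; others in the source may bear on it.

Of the compounds shown here, three sharing one core have been tested in a functional assay on the whole organism for inhibition, with Rattus norvegicus as the target, read by paw edema, with a stated time of 30 min, at a dose of 80 mg/kg by the oral route; on this read-out higher numbers stand for a stronger effect at the one dose given and lower numbers for a weaker effect. Compound 1 `Brc1ccccc1OCC1=NCCO1` gives 62.8%, compound 2 `Clc1ccccc1OCC1=NCCO1` gives 45.5%, and compound 3 `Cc1cc(OCC2=NCCO2)ccc1Cl` gives 77.1%. Compound 2 thus has the lowest of the three numbers; the nearest is compound 1, and the furthest is compound 3, which differs from it in more than one place and so allows no single-change comparison.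

Going by the values given here, the one single-change step measured so far is a number 17.3 percentage points lower from compound 1 to compound 2 (beyond the scatter), a modest but genuine fall when the heavier halogen is swapped for the lighter one.

Compound 4 `Fc1ccccc1OCC1=NCCO1` carries the same change one step further: fluoro in place of chloro on an aromatic carbon. Only the bromo-to-chloro step bears on it, and it pointed downward. The expectation for compound 4 is therefore a further fall, of about a number 9.5 percentage points lower from compound 2 to compound 4 (within the scatter), though a single step is a thin basis and no change beyond the scatter would not be surprising. Compound 4 is estimated at 36%, with a likely range from 18% to 56%.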

Compound 4, a percentage reported as inhibition, in the whole organism at one dose (the size of the read-out at that dose, not a potency): 60.1%
For compound 4 the middle estimate is 24.1 percentage points below the measured one; measured number above the stated range.
By their numbers in this assay, from the lowest: compound 2; then compounds 4 and 1 (each within the scatter of the next); then compound 3.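

The change of fluoro in place of chloro gives a number 14.6 percentage points higher from compound 2 to compound 4 (beyond the scatter) and so reverses the fall seen from bromo to chloro; on this aromatic carbon, the effect in this assay does not follow halogen size in one direction. Fluoro and bromo, the smallest and largest of the three halogens, give a number 2.7 percentage points lower from compound 1 to compound 4 (within the scatter) and cannot be told apart at this dose. Compound 2 is the one that stands apart, with chloro giving a lower number than either of the other two halogens.

From the compounds shown here alone, whether other groups on this carbon, such as a methoxy group, an amine or a longer chain, would match fluoro and bromo or fall to the level of chloro remains open. Going by these compounds alone, nothing measured so far offers a reason for the low number with chloro.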